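A few compounds are considered here, and "the series" means these few. Any claim that something is new, unique, unknown or untested is made for them only; others in the source may bear on it.

In a toxicity assay on THP-1 cells (Homo sapiens) for inhibition (a higher number here means that more compound is tolerated, a lower number that less compound is tolerated), compound 3 `COc1ccc(-c2cnc(NC(=O)c3ccc(Cl)cc3)n2C)cc1` reports only a limit, > 100000 nM, and no number. This places compound 3 at the limit of > 100000 nM in this assay, at which 2 of the 3 values shown sit. Compound 2 `COc1ccc(-c2cnc(NC(=O)C3CCOCC3)n2C)cc1` also reports only a limit, > 100000 nM.

The next compound, compound 4 `COc1ccc(-c2cnc(NC(=O)c3ccccc3Cl)n2C)cc1`, has not yet been measured. It keeps the atoms of compound 3 but joins them differently, with 2-chlorophenyl in place of 4-chlorophenyl on a carbonyl carbon.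

One measured step changes the group at this same place: a step that the two limits leave unreadable from compound 2 to compound 3. Both of its ends are limits, so it offers no size to carry over to the new change. Compound 1 `Cn1c(-c2ccccc2)cnc1NC(=O)c1ccccc1Cl` has a different core substitution but also bears 2-chlorophenyl on a carbonyl carbon. It too reports only a limit, > 50000 nM.

Going by the values given here, no measured compound in this small set has a numerical value, so the data give no sign of a change in either direction. The expected step is a number no higher from compound 3 to compound 4 (the limit leaves the size open), which would be none beyond the scatter. Compound 4 is expected to be tolerated much as compound 3 is, and a limit rather than a number is the likely report. For compound 4 the estimated value is 100000 nM, with an expected range of 50000 nM to 200000 nM.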

Compound 4, half-maximal cytotoxic concentration: > 50000 nM
Compound 4: a limit, no number; the forecaster's own chance of this, stated with the estimate: 85%; the middle value lies beyond the limit too.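

The steps to compound 4 from compound 1, compound 2 and compound 3 cannot be read in this assay: all four compounds report limits and no numbers. The compounds shown leave open at what concentration any of them becomes toxic to these cells, and whether 2-chlorophenyl in place of 4-chlorophenyl shifts that concentration at all.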